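The source may report more compounds than this note shows. Statements on the series, on what has been measured and on what is new or still open speak of the compounds shown alone.

Measured in a functional assay on M21 cells (Homo sapiens) for antiproliferative activity, read by sulforhodamine B assay, with a stated time of 48 h; on this read-out higher numbers stand for weaker inhibition and lower numbers for stronger inhibition:

Compound 1, `CC(C)c1ccccc1OS(=O)(=O)c1ccc(NC(=O)CCCl)cc1`: 14000 nM
Compound 2, `O=C(CCCl)Nc1ccc(S(=O)(=O)Oc2ccccc2I)cc1`: 12000 nM
Compound 3, `CC(C)c1ccccc1OS(=O)(=O)c1ccc(NC(=O)CCCCl)cc1`: 5100 nM

Compound 4, `O=C(CCCCl)Nc1ccc(S(=O)(=O)Oc2ccccc2I)cc1`, has not yet been measured in this assay. Compound 4 differs from compound 3 by iodo in place of isopropyl on an aromatic carbon. The same change, made from compound 1 to compound 2, reads iodo in place of isopropyl on an aromatic carbon and gave a 1.2-fold lower number from compound 1 to compound 2 (0.07 log units; within the scatter). The two cores differ by chloromethyl in place of chloro on a saturated chain carbon, two bonds along the chain from a carbonyl carbon, a change that gave a 2.7-fold lower number from compound 1 to compound 3 (0.44 log units; beyond the scatter), so compound 3 carries the lowest number of the three measured, with both other compounds beyond the scatter from it. Within the data shown here, because a 1.2-fold lower number from compound 1 to compound 2 (0.07 log units; within the scatter) is the one measured instance of this change, the expected step for compound 4 is a 1.2-fold lower number from compound 3 to compound 4 (0.07 log units; within the scatter), of the same small size. On that basis the estimate for compound 4 in this assay is 4300 nM.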

Compound 4, half-maximal inhibitory concentration: 7200 nM
The estimate for compound 4 lay 1.7-fold (0.22 log units) below the measured number; measured number inside the range.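

In this assay, iodo in place of isopropyl gives a 1.4-fold higher number from compound 3 to compound 4 (0.15 log units; within the scatter), and its two readings agree: the same change on two cores in this assay, a 1.2-fold lower number (0.07 log units; within the scatter) from compound 1 to compound 2 and a 1.4-fold higher number (0.15 log units; within the scatter) from compound 3 to compound 4, 1.6-fold (0.22 log units) apart, within the scatter of two such steps. Chloromethyl in place of chloro on the chain gives a 1.7-fold lower number from compound 2 to compound 4 (0.22 log units; within the scatter), and these two readings also agree: the same change on two cores in this assay, a 2.7-fold lower number (0.44 log units; beyond the scatter) from compound 1 to compound 3 and a 1.7-fold lower number (0.22 log units; within the scatter) from compound 2 to compound 4, 1.6-fold (0.22 log units) apart, within the scatter of two such steps. Among these compounds, both changes therefore carry between these two cores without a detectable difference, but each rests on only two readings, so this does not establish that they would carry to other cores, and the chain step on the iodo core does not by itself separate compound 2 from compound 4.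

Still open, from the compounds shown here alone, is whether an amine in place of the chain chloro, or a longer chain, would follow the same course. Also open, going by these compounds, is how a methoxy group in place of iodo or isopropyl would read.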